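A few compounds are considered here, and "the series" means these few. Any claim that something is new, unique, unknown or untested is made for them only; others in the source may bear on it.

In a functional assay on MCF7 cells (Homo sapiens) for inhibition, read by sulforhodamine B assay (on this read-out higher numbers stand for weaker inhibition and lower numbers for stronger inhibition), compound 2 `O=C1C(Nc2cccc(Cl)c2)=CC(=O)c2c1nc1n2[C@H]2OC[C@@H](O)[C@H]2OC1` gives 2970 nM, the smaller of the two numbers shown, and compound 1 `COc1cccc(NC2=CC(=O)c3c(nc4n3[C@H]3OC[C@@H](O)[C@H]3OC4)C2=O)c1` gives 3830 nM, a value within the usual scatter of it. Compound 3 `O=C1C=C(NC2CCCCC2)C(=O)c2c1nc1n2[C@H]2OC[C@@H](O)[C@H]2OC1` reaches only the limit > 8000 nM in this assay. The step of a 1.3-fold lower number from compound 1 to compound 2 (0.11 log units; within the scatter) shows that exchanging the group on the amine nitrogen between these two aromatic variants left the number essentially unchanged. Compound 4 `O=C1C(Nc2ccc(I)cc2)=CC(=O)c2c1nc1n2[C@H]2OC[C@@H](O)[C@H]2OC1` carries 4-iodophenyl in place of 3-chlorophenyl on an amine nitrogen. Going by the values given here, no measured step covers this exchange directly; the only step that keeps an aromatic ring, a 1.3-fold lower number from compound 1 to compound 2 (0.11 log units; within the scatter), was small, while the limit of > 8000 nM in this assay, at which 1 of the 3 values shown sits, marks compound 3 as the one without a number. Compound 4 is therefore expected to show a 1.1-fold higher number from compound 2 to compound 4 (0.03 log units; within the scatter), a step not beyond the scatter. The estimate for compound 4 is 3200 nM, with a range from 1300 nM to 8000 nM.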

Compound 4, half-maximal inhibitory concentration: 3890 nM
Beside the measured number, compound 4's estimate is 1.2-fold (0.08 log units) below it; the measured number falls inside the stated range.
By their numbers in this assay, from the lowest: compounds 2, 1 and 4 (each within the scatter of the next). At a limit, above all of these: compound 3.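

With the 4-iodophenyl group on the amine nitrogen, this assay gives a 1.3-fold higher number from compound 2 to compound 4 (0.12 log units; within the scatter) and a 1.0-fold higher number from compound 1 to compound 4 (0.01 log units; within the scatter). Going by these compounds alone, a third substituted phenyl group, now carrying iodine rather than chlorine or methoxy, therefore stays within the scatter of the other two, which the single earlier step between aromatic variants could not show. Compound 3 remains a limit, not a number: the limit of > 8000 nM in this assay, at which 1 of the 4 values shown sits.

Still open, on these data alone, is whether an unsubstituted phenyl, a pyridyl ring, or a phenyl ring bearing an amine or a carboxylic acid would give a number beyond the scatter of these three.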